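Chloro added beside a trifluoromethyl on a sulfonamide aryl

The source may hold more compounds than are shown below. What is called first, only, known or untested is meant among the compounds shown, and "the series" means these compounds.

Measured compounds:
Compound 1, `O=S(=O)(Nc1ccc(-c2nc3cc(NS(=O)(=O)c4ccc(Cl)s4)ccc3o2)cc1)c1ccc(Cl)s1`: 5900 nM
Compound 2, `O=[N+]([O-])c1cc(S(=O)(=O)Nc2ccc3oc(-c4ccc(NS(=O)(=O)c5ccc(Cl)s5)cc4)nc3c2)ccc1Cl`: 1000 nM
Compound 3, `O=S(=O)(Nc1ccc2oc(-c3ccc(NS(=O)(=O)c4ccc(Cl)s4)cc3)nc2c1)c1cccc(C(F)(F)F)c1`: 5000 nM

In an assay for inhibition of HSP60/HSP10 (Homo sapiens), with a stated time of 60 min (a higher number here means a weaker inhibitor, a lower number a stronger inhibitor), compound 3 gives 5000 nM, the second highest of the three numbers. Its nearest neighbour is compound 1, and the two values lie within the scatter of each other, so no order between them is claimed: a 1.2-fold lower number from compound 1 to compound 3 (0.07 log units; within the scatter). Compound 2 stands apart, as a 5.0-fold higher number from compound 2 to compound 3 (0.70 log units; beyond the scatter) shows, a modest step beyond the scatter.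

Compound 4, `O=S(=O)(Nc1ccc2oc(-c3ccc(NS(=O)(=O)c4ccc(Cl)s4)cc3)nc2c1)c1ccc(Cl)c(C(F)(F)F)c1`, is compound 3 with one change: chloro in place of hydrogen on an aromatic carbon. Among the compounds with values here, two steps bear on it. The change from compound 1 to compound 2, a 5.9-fold lower number from compound 1 to compound 2 (0.77 log units; beyond the scatter), brought a 4-chloro-3-nitrophenyl onto the sulfonyl sulfur and lowered the number modestly; the change from compound 2 to compound 3, a 5.0-fold higher number from compound 2 to compound 3 (0.70 log units; beyond the scatter), went the other way. Compound 4 carries a 4-chloro-3-(trifluoromethyl)phenyl, closer in make-up to the aryl of compound 2 than compound 3 is. Compound 4 is therefore expected to give a lower number than compound 3, by a step of about a 2.0-fold lower number from compound 3 to compound 4 (0.30 log units; within the scatter), though a step no larger than the scatter is also possible. The estimate for compound 4 in this assay is 2500 nM, with a range from 1000 nM to 6000 nM.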

Compound 4, half-maximal inhibitory concentration: 2400 nM
Estimate against measurement, compound 4: 1.0-fold (0.02 log units) above, and the stated range covers the measured number.
By their numbers in this assay, from the lowest: compound 2; then compound 4; then compounds 3 and 1 (each within the scatter of the next).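

In this assay, within the data shown here, chloro in place of hydrogen on the aromatic carbon ortho to a trifluoromethyl group gives a 2.1-fold lower number from compound 3 to compound 4 (0.32 log units; beyond the scatter), the first step that isolates this single atom on the six-membered aryl, since the earlier steps exchanged whole groups on the sulfonyl sulfur. With that chloro held in place, trifluoromethyl in place of nitro gives a 2.4-fold higher number from compound 2 to compound 4 (0.38 log units; beyond the scatter), so the choice of that neighbouring group still registers beyond the scatter, while a 2.5-fold lower number from compound 1 to compound 4 (0.39 log units; beyond the scatter) sets the 4-chloro-3-(trifluoromethyl)phenyl apart from the 5-chlorothiophen-2-yl, a separation that compound 3, within the scatter of compound 1, did not show. Nothing available here accounts for any of these steps.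

The compounds shown leave open whether chloro gives a similar step when nitro rather than trifluoromethyl is its neighbour, as no compound carries a 3-nitrophenyl to pair with compound 2. They also leave open how a fluoro, a methyl, an amine or a carboxylic acid would compare with chloro on this same carbon.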